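Trifluoromethyl for methoxy at the limit of the assay

A few compounds are considered here, and "the series" means these few. Any claim that something is new, unique, unknown or untested is made for them only; others in the source may bear on it.

Three compounds share one core, and all three sit at limits in an assay on cells for inhibition of S-adenosylmethionine decarboxylase proenzyme (Homo sapiens), read by mass spectrometry, at pH 7.2; a lower number here means a stronger inhibitor, a higher number a weaker inhibitor. Compound 1 `Cc1cc(Nc2cc(Cl)cc(S(F)(F)(F)(F)F)c2)nc(N)n1` gives > 180000 nM, a limit of the assay. Compound 2 `Cc1cc(Nc2cc(Cl)c(C)c(Cl)c2)nc(N)n1` gives > 63000 nM, also a limit. Compound 3 `COc1ccc(-c2cc(Cl)cc(Nc3cc(C)nc(N)n3)c2)cc1` gives > 180000 nM, again a limit, so the step that the two limits leave unreadable from compound 1 to compound 3 cannot be read. Compound 3 thus stands at the limit of > 180000 nM in this assay, at which 2 of the 3 values shown sit, while the limit of > 63000 nM in this assay, at which 1 of the 3 values shown sits, holds the remaining one. Compound 4 `Cc1cc(Nc2cc(Cl)cc(-c3ccc(C(F)(F)F)cc3)c2)nc(N)n1` differs by trifluoromethyl in place of methoxy on an aromatic carbon. No measured step bears on this change, and nothing shown points to a readable value. Compound 4 is therefore expected to stay at the limit, with a step that the limit leaves unreadable from compound 3 to compound 4 that is not readable. The estimate for compound 4 is 200000 nM, between 50000 nM and 600000 nM.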

Compound 4, half-maximal inhibitory concentration: > 21000 nM
Compound 4 was reported as a limit (the forecaster's own chance of this, stated with the estimate: 85%); the middle value is on the limit's open side.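

In this assay compound 4 gives > 21000 nM, which is a limit, so the step from compound 3 to compound 4 cannot be read. The compounds shown leave open whether trifluoromethyl in place of methoxy changes inhibition at all.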